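Replacing the sulfated tail of compound 2 with a short alkyl ether

The compounds below may be only part of what the source reports. "The series", "measured", "known", "first", "only" and "open" are said of these compounds alone.

Two compounds share a lipopeptide core. Compound 1 `CCCCCCCCCCCC(=O)OC[C@H](CSC[C@@H](N)C(=O)NCCCS(=O)(=O)O)OC(=O)CCCCCCCCCCC` gives 5560 nM in an assay on HEK293 cells for agonist activity at Toll-like receptor 2 (Homo sapiens); a higher number here means that more compound is needed for the effect, a lower number that less compound is needed. Going by the values given here, compound 2 `CCCCCCCCCCCC(=O)OC[C@H](CSC[C@@H](N)C(=O)NCCOCCOS(=O)(=O)O)OC(=O)CCCCCCCCCCC` gives 61 nM in this assay, the lowest of the two numbers, and the only step on record, a 91-fold lower number from compound 1 to compound 2 (1.96 log units; beyond the scatter), is large. Compound 3 `CCCCCCCCCCCC(=O)OC[C@H](CSC[C@@H](N)C(=O)NC(CC)COC)OC(=O)CCCCCCCCCCC` is not yet measured; it differs from compound 2 by 1-(methoxymethyl)propyl in place of 2-(2-(sulfooxy)ethoxy)ethyl on an amide-type nitrogen. Among the compounds with values here, the one step on record bears on this only indirectly: it shows that a shift of the sulfated group alone moves the number far, while compound 3 drops that group altogether and keeps a single ether oxygen. Within the data shown here, no step on record tests such a removal, so the expectation is uncertain. Compound 3 is estimated to give a clearly higher number, with a 25-fold higher number from compound 2 to compound 3 (1.39 log units; beyond the scatter) as the expected step. The estimate for compound 3 is 1500 nM, within a range from 150 nM to 15000 nM.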

Compound 3, half-maximal effective concentration: 71.8 nM
Compound 3: the middle estimate sits 21-fold (1.32 log units) above what was measured, outside the stated range (below it).
By their numbers in this assay, from the lowest: compounds 2 and 3 (each within the scatter of the next); then compound 1.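

In this assay, a sulfated tail proves unnecessary for a low number on this amide-type nitrogen: a 1.2-fold higher number from compound 2 to compound 3 (0.07 log units; within the scatter), even though 2-(2-(sulfooxy)ethoxy)ethyl, with 10 heavy atoms, gives way to 1-(methoxymethyl)propyl, with 6 heavy atoms and no sulfur. The same group also gives a 77-fold lower number from compound 1 to compound 3 (1.89 log units; beyond the scatter), so among these three compounds, the only group that goes with a high number is 3-sulfopropyl, and sulfur alone does not separate high from low. No accompanying measurement offers an explanation for this result.

As far as these compounds go, whether the single ether oxygen matters remains open, as a plain butyl chain would test that directly. Also open, from the compounds shown here alone, are the branching in 1-(methoxymethyl)propyl and what a carboxylic acid or an amine would give at the end of the chain.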